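Swapping 4-bromophenyl for 2,4,6-trimethylphenyl in a small series

The compounds below may be only part of what the source reports. "The series", "measured", "known", "first", "only" and "open" are said of these compounds alone.

Within the data shown here, in a functional assay on HeLa cells (Homo sapiens) for inhibition, read by MTT assay, with a stated time of 48 h (on this read-out lower numbers stand for stronger inhibition and higher numbers for weaker inhibition), compound 3 `Cc1c(NC(=O)CN2C(=O)S/C(=C\c3ccc(Br)cc3)C2=O)c(=O)n(-c2ccccc2)n1C` gives 9410 nM, the lowest of the three numbers measured so far. In the same test, compound 1 `COc1ccc(/C=C2\SC(=O)N(CC(=O)Nc3c(C)n(C)n(-c4ccccc4)c3=O)C2=O)cc1` gives 64800 nM, and compound 2 `Cc1c(NC(=O)CN2C(=O)S/C(=C\c3ccc([N+](=O)[O-])cc3)C2=O)c(=O)n(-c2ccccc2)n1C` gives 77200 nM.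

The next compound, compound 4 `Cc1cc(C)c(/C=C2\SC(=O)N(CC(=O)Nc3c(C)n(C)n(-c4ccccc4)c3=O)C2=O)c(C)c1`, is changed at the group these three compounds vary: 2,4,6-trimethylphenyl in place of 4-bromophenyl on a double-bonded chain carbon bound to a double-bonded ring carbon. The measured steps bear on this only in part. Bromo in place of methoxy gave a 6.9-fold lower number from compound 1 to compound 3 (0.84 log units; beyond the scatter), and bromo in place of nitro gave an 8.2-fold lower number from compound 2 to compound 3 (0.91 log units; beyond the scatter). Nitro in place of methoxy gave a 1.2-fold higher number from compound 1 to compound 2 (0.08 log units; within the scatter), a step that does not stand out from the scatter. Among these three compounds, then, only the one carrying bromine stands apart, and compound 4 carries no bromine.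

A move back toward higher numbers in this assay is therefore expected, resting on the two bromo steps above. Among the measured compounds shown here, no compound with a 2,4,6-trimethylphenyl group has been measured yet, which leaves the size open, and a partial return seems more likely than a full one. The expected change is a 3.2-fold higher number from compound 3 to compound 4 (0.50 log units; beyond the scatter). For compound 4 the estimated value is 30000 nM, with an expected range from 10000 nM to 80000 nM.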

Compound 4, half-maximal inhibitory concentration: 60900 nM
Estimate against measurement, compound 4: 2.0-fold (0.31 log units) below, and the stated range covers the measured number.
By their numbers in this assay, from the lowest: compound 3; then compounds 4, 1 and 2 (each within the scatter of the next).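

In this assay the swap of 4-bromophenyl for 2,4,6-trimethylphenyl gives a 6.5-fold higher number from compound 3 to compound 4 (0.81 log units; beyond the scatter) and so takes back all of the gain seen with bromine and not just part of it, as a 1.1-fold lower number from compound 1 to compound 4 (0.03 log units; within the scatter) and a 1.3-fold lower number from compound 2 to compound 4 (0.10 log units; within the scatter) are steps that stay inside the usual scatter. Three quite different groups at this place (4-methoxyphenyl, 4-nitrophenyl and 2,4,6-trimethylphenyl) now sit level with one another, and compound 3 alone stands apart among the four compounds, so its edge is not something peculiar to a comparison with methoxy or nitro. Nothing available here explains why the compound with bromine behaves differently.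

From the compounds shown here alone, whether bromine itself matters or any similar group would serve remains open, and a 4-chlorophenyl or 4-iodophenyl group at the same place would help to separate those two readings. Going by these compounds, it is also open whether a single methyl group, as in 4-methylphenyl, would match the 2,4,6-trimethylphenyl result or come closer to compound 3.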